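A furan for a thiophene on an inactive core

The source may report more compounds than this note shows. Statements on the series, on what has been measured and on what is new or still open speak of the compounds shown alone.

Compound 1, `Oc1ccccc1-c1cc(-c2ccsc2)cc(-c2ccccc2O)n1`, gives > 50000 nM in a functional assay on T47D cells (Homo sapiens) for cytotoxicity, read by CCK-8 assay; a higher number here means a weaker inhibitor, a lower number a stronger inhibitor; this is a limit of the assay, not a number. Compound 2, `Oc1ccc(-c2cc(-c3ccsc3)cc(-c3ccccc3O)n2)cc1`, gives > 50000 nM in this assay; this too is a limit.

Among the compounds with values here, compound 1 therefore stands only at a limit, and the single measured step, a step that the two limits leave unreadable from compound 1 to compound 2, cannot be read, since both values sit at the limit of > 50000 nM in this assay, at which 2 of the 2 values shown sit. Compound 3, `Oc1ccccc1-c1cc(-c2ccoc2)cc(-c2ccccc2O)n1`, differs from compound 1 by furan-3-yl in place of thiophen-3-yl on an aromatic carbon. Within the data shown here, no measured step touches this position, so nothing among the measured compounds points to a gain or a loss; the one step measured on the shared core left the value at the limit. Compound 3 is therefore expected to remain at or beyond the limit, estimated at 60000 nM with a range from 20000 nM to 200000 nM. This means an expected step that the limit leaves unreadable from compound 1 to compound 3, none beyond the scatter.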

Compound 3, half-maximal inhibitory concentration: > 50000 nM
Compound 3 was reported as a limit; the forecaster's own chance of this, stated with the estimate: 85%; the middle value lies beyond the limit too.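

Compound 3, like compound 1, stands only at a limit in this assay, so the step between them, furan-3-yl in place of thiophen-3-yl, cannot be read: the limit of > 50000 nM in this assay, at which 3 of the 3 values shown sit.

The compounds shown leave open how far each lies beyond that limit, and whether any change on the shared core gives a readable value.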